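Working notes: the step from compound 3 to compound 4

The compounds below may be only part of what the source reports. "The series", "measured", "known", "first", "only" and "open" are said of these compounds alone.

In an ADME assay on MT4 cells (Homo sapiens) for cytotoxicity (a lower number here means that less compound is tolerated, a higher number that more compound is tolerated), compound 1 (`COC(=O)N[C@H](C(=O)NN(CCC[C@@](O)(Cc1ccccc1)C(=O)N[C@H]1c2ccccc2C[C@H]1O)Cc1ccc(C#N)cc1)C(C)(C)C`) gives > 10000 nM as a limit of the assay. Compound 2 (`COC(=O)N[C@H](C(=O)NN(CCC[C@@](O)(Cc1ccccc1)C(=O)N[C@H]1c2ccccc2C[C@H]1O)Cc1ccc(-c2ccccn2)cc1)C(C)(C)C`) gives > 10000 nM as a limit as well. Compound 3 (`COC(=O)N[C@H](C(=O)NN(CCC[C@@](O)(Cc1ccccc1)C(=O)N[C@H]1c2ccccc2C[C@H]1O)Cc1ccc(-c2noc(C)n2)cc1)C(C)(C)C`) gives > 10000 nM as a limit too, so it has no exact number and stands level with neither more nor less certainty than the other two. All three share one limit (the limit of > 10000 nM in this assay, at which 3 of the 3 values shown sit).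

Compound 4 (`COC(=O)N[C@H](C(=O)NN(CCC[C@@](O)(Cc1ccccc1)C(=O)N[C@H]1c2ccccc2C[C@H]1O)Cc1ccc(-c2cn3ccsc3n2)cc1)C(C)(C)C`) follows from compound 3 through a group of 8 heavy atoms (5 carbon, 2 nitrogen, 1 sulfur; 2 five-membered aromatic rings with 2 hetero atoms each) in place of a group of 6 heavy atoms (3 carbon, 2 nitrogen, 1 oxygen; one five-membered aromatic ring with 3 hetero atoms), on an aromatic carbon and the rest of the structure stays the same.

Three measured steps exchange a group at this place. They are a step that the two limits leave unreadable from compound 1 to compound 2 and a step that the two limits leave unreadable from compound 1 to compound 3 and a step that the two limits leave unreadable from compound 2 to compound 3 and none of them has a readable size. Each of the three groups tried here leaves the compound at the limit, and the group entering compound 4 has not been tested. On the basis of a step that the two limits leave unreadable from compound 1 to compound 3 and a step that the two limits leave unreadable from compound 2 to compound 3 no step beyond the scatter is expected in this assay and no direction can be assigned. The expected change is a number no higher from compound 3 to compound 4 (the limit leaves the size open) as an estimate only. For compound 4 the estimate is 10000 nM with an expected range from 5000 nM to 20000 nM and another report as a limit is the likeliest outcome.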

Compound 4, half-maximal cytotoxic concentration: > 10000 nM
Compound 4 was reported as a limit; the forecaster's own chance of this, stated with the estimate: 80%; the middle value sits exactly at the limit.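

In this assay compound 4 gives > 10000 nM, a limit of the assay. The steps to compound 4 from compound 1, compound 2 and compound 3 cannot be read: the limit of > 10000 nM in this assay, at which 4 of the 4 values shown sit.

The compounds shown leave open whether any group at this place on the aromatic carbon changes the result in this assay, and where any of the four compounds would give an exact value.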